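The source may hold more compounds than are shown below. What is called first, only, known or untested is meant among the compounds shown, and "the series" means these compounds.

In a functional assay on FaDu cells (Homo sapiens) for antiproliferative activity, read by sulforhodamine B assay, with a stated time of 48 h (on this read-out lower numbers stand for stronger inhibition and higher numbers for weaker inhibition), compound 1 `CCCCN(C)C(=O)CCCCOc1cc(OC)c(OC)c2oc(-c3ccc(OC)cc3)c(O)c(=O)c12` gives 22000 nM. Compound 2 `CCCCCN(C)C(=O)CCCCCOc1cc(OC)c(OC)c2oc(-c3ccc(OC)cc3)c(O)c(=O)c12` gives > 40000 nM, which is a limit of the assay and not a number. Compound 3 `COc1ccc(-c2oc3c(OC)c(OC)cc(OCCCCCC(=O)N4CCN(C)CC4)c3c(=O)c2O)cc1` differs from compound 2 at the amide end: 4-methylpiperazin-1-yl in place of methyl(pentyl)amino on a carbonyl carbon. Among the compounds with values here, the only measured step, an at least 1.8-fold higher number from compound 1 to compound 2 (0.25 log units; that floor lies within the scatter), also alters the amide end, and it sets only a floor, so it offers no firm size to carry over. No step beyond the scatter is therefore expected in this assay, and the expected change is an at least 1.1-fold lower number from compound 2 to compound 3 (0.05 log units; that floor lies within the scatter). Compound 3 is estimated at 35000 nM, with an expected range from 12000 nM to 80000 nM.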

Compound 3, half-maximal inhibitory concentration: 15800 nM
Compound 3: the middle estimate sits 2.2-fold (0.35 log units) above what was measured; low and high end bracket the measured number.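

In this assay, within the data shown here, the 4-methylpiperazin-1-yl ring in place of methyl(pentyl)amino on the carbonyl carbon gives an at least 2.5-fold lower number from compound 2 to compound 3 (0.40 log units; beyond the scatter), the first change at the amide end that clearly exceeds the scatter. Compound 2 stands at > 40000 nM, which is a limit of the assay and not a number, so that size is only a floor: the limit of > 40000 nM in this assay, at which 1 of the 3 values shown sits. Against the butyl(methyl)carbamoyl end on the shorter chain, the ring shows a 1.4-fold lower number from compound 1 to compound 3 (0.14 log units; within the scatter), so those two stay level.

The compounds shown leave open whether the ring itself or its second nitrogen matters. A morpholine or a piperidine on this carbonyl carbon would tell the two apart.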